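Methyl on the fused ring of the pyrrolidine dithiocarbamate

The compounds below may be only part of what the source reports. "The series", "measured", "known", "first", "only" and "open" are said of these compounds alone.

Compound 2 `O=c1c(CSC(=S)N2CCCC2)coc2ccccc12` gives 3800 nM in a functional assay on MDA-MB-435S cells (Homo sapiens) for antiproliferative activity, read by MTT assay, with a stated time of 72 h (a higher number here means a weaker inhibitor, a lower number a stronger inhibitor), the highest of the three numbers recorded. Compound 3 `CN1CCN(C(=S)SCc2coc3ccccc3c2=O)CC1` sits nearest at 2200 nM, and compound 1 `Cc1ccc2c(=O)c(CSC(=S)N3CCCCC3)coc2c1` furthest at 1700 nM. Going by the values given here, the one single-point step on record, a 1.7-fold lower number from compound 2 to compound 3 (0.24 log units; within the scatter), concerns the amine on the thiocarbonyl carbon and not the fused ring.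

Compound 4 `Cc1ccc2c(=O)c(CSC(=S)N3CCCC3)coc2c1` is not yet measured. It differs from compound 2 by methyl in place of hydrogen on an aromatic carbon, the site being on an aromatic carbon of a six-membered aromatic ring of carbon only, part of a fused system of two rings. Among the compounds with values here, no measured step isolates this change: compound 1 carries the same methyl but also a different amine, so its gap to compound 2 cannot be assigned to the methyl alone. The step to compound 4 in this assay is therefore expected to be small, leaning toward a lower number, a 1.5-fold lower number from compound 2 to compound 4 (0.18 log units; within the scatter). Compound 4 is expected to give about 2500 nM, between 1200 nM and 5500 nM.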

Compound 4, half-maximal inhibitory concentration: 1900 nM
The estimate for compound 4 lay 1.3-fold (0.12 log units) above the measured number; the measured number falls inside the stated range.
By their numbers in this assay, from the lowest: compounds 1, 4, 3 and 2 (each within the scatter of the next, the first and the last beyond it).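

In this assay the methyl in place of hydrogen on an aromatic carbon now has a step of its own, with the amine held as pyrrolidin-1-yl (a 2.0-fold lower number from compound 2 to compound 4 (0.30 log units; within the scatter)). With the methyl held in place, the amine on the thiocarbonyl carbon also has its first step on this methyl-bearing core (a 1.1-fold higher number from compound 1 to compound 4 (0.05 log units; within the scatter)), so pyrrolidin-1-yl and piperidin-1-yl are not told apart here. Neither of these one-place steps lies beyond the scatter, and nothing available explains either of them.

Going by these compounds, whether a chlorine or a methoxy group on the same aromatic carbon would give a step beyond the scatter remains open. Also open, on these data alone, is the step for this methyl on the 4-methylpiperazin-1-yl dithiocarbamate, compound 3.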